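This account rests on a few compounds, and the source may have more. Where it says the series, first, only, none or still open, it means among the compounds named here.

Of the compounds shown here, two have been tested in an assay on isolated protein for inhibition of protein kinase C delta type (Homo sapiens), read by TR-FRET, with a stated time of 2 h; on this read-out lower numbers stand for stronger inhibition and higher numbers for weaker inhibition. Compound 1 `N#Cc1cnc(NCc2cnccc2C(F)(F)F)cc1NC[C@H]1C[C@H](O)C1` reaches only the limit of the assay, > 10000 nM, so no number is obtained for it. Among the compounds with values here, compound 2 `N#Cc1cnc(NCc2cnccc2C(F)(F)F)cc1N[C@H]1CC[C@@H](O)CC1` gives 4500 nM in this assay, the only number obtained so far. Within the data shown here, the step of an at least 2.2-fold lower number from compound 1 to compound 2 (0.34 log units; beyond the scatter) is the one measured change, and it rests on (the limit of > 10000 nM in this assay, at which 1 of the 2 values shown sits), so only its smallest size is known.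

Compound 3 `N#Cc1cnc(NCc2cnccc2C(F)(F)F)cc1NC[C@H]1CC[C@@H](O)CC1` differs from compound 2 in one place: (4-hydroxycyclohexyl)methyl in place of 4-hydroxycyclohexyl on a nitrogen on an aromatic ring. Among the measured compounds shown here, the one measured step swapped both ring size and the way the ring hangs on the nitrogen, so it bears on this change only loosely; the compound carrying the extra carbon was the weaker one. A modest weakening, a 1.6-fold higher number from compound 2 to compound 3 (0.19 log units; within the scatter), is therefore expected, though within wide uncertainty. Compound 3 is estimated at 7000 nM in this assay, plausibly anywhere from 2500 nM to 20000 nM.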

Compound 3, half-maximal inhibitory concentration: 500 nM
Compound 3: the middle estimate sits 14-fold (1.15 log units) above what was measured, and the stated range ends above it.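

Replacing 4-hydroxycyclohexyl with (4-hydroxycyclohexyl)methyl on this nitrogen gives a 9.0-fold lower number from compound 2 to compound 3 (0.95 log units; beyond the scatter) in this assay, so with the ring size held constant, the extra carbon goes with stronger inhibition, an effect the earlier pair could not isolate. With the saturated chain carbon kept, 4-hydroxycyclohexyl in place of 3-hydroxycyclobutyl gives an at least 20-fold lower number from compound 1 to compound 3 (1.30 log units; beyond the scatter), which shows that the ring also matters at this position. Only the smallest size of that second step is known, as it rests on a limit of the assay: the limit of > 10000 nM in this assay, at which 1 of the 3 values shown sits.

The compounds shown leave open whether a longer chain, such as (4-hydroxycyclohexyl)ethyl, would continue this trend or reverse it. They also leave open whether the hydroxyl on the ring could be replaced by an amine or a carboxylic acid.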